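This account rests on a few compounds, and the source may have more. Where it says the series, first, only, none or still open, it means among the compounds named here.

Compound 1 `O=CN(O)C(CCc1ccccc1)CS(=O)(=O)N1CCN(c2ccc(F)cc2)CC1` was examined in an ADME assay for inhibition of Bile salt export pump (Homo sapiens), read by scintillation counting, with a stated time of 5 min; a higher number here means a weaker inhibitor, a lower number a stronger inhibitor. In this assay compound 1 gives < 10000 nM, which is a limit of the assay and not a number. Compound 2 `O=C(NO)C(CCc1ccccc1)CS(=O)(=O)N1CCN(c2ccc(F)cc2)CC1` differs from compound 1 only in a hydroxycarbamoyl in place of formyl(hydroxy)amino. In this assay compound 2 gives < 10000 nM, again a limit. The step that the two limits leave unreadable from compound 1 to compound 2 therefore cannot be read, since the limit of < 10000 nM in this assay, at which 2 of the 2 values shown sit, covers both values. Going by the values given here, compound 3 `O=CN(O)C(CCc1ccccc1)CS(=O)(=O)N1CCN(c2ccc(Cl)cn2)CC1` carries 5-chloropyridin-2-yl in place of 4-fluorophenyl on an amine nitrogen in a ring, a change on which no measured step bears. Compound 3 is expected to give 4000 nM (range 800 nM to 10000 nM), an estimated step that the limit leaves unreadable from compound 1 to compound 3 that is expected to stay within the scatter.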

Compound 3, half-maximal inhibitory concentration: < 10000 nM
Compound 3 gave a limit, no number; the forecaster's own chance of this, stated with the estimate: 70%; the middle value lies beyond the limit too.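

In this assay, going by these compounds alone, compound 3 gives < 10000 nM, a limit of the assay and not a number, so no step from compound 1 to compound 3 can be read. The compounds shown leave open how strongly each inhibits, and whether 5-chloropyridin-2-yl in place of 4-fluorophenyl changes anything.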